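Swapping Chloro for Methyl on the Aryl Ring

The source may hold more compounds than are shown below. What is called first, only, known or untested is meant among the compounds shown, and "the series" means these compounds.

Compound 1, `CCC(CC)Nc1nc(C)nc2c(-c3cc(F)c(OC)cc3Cl)c(C)nn12`: 1 nM
Compound 2, `CCCC(C)Nc1nc(C)nc2c(-c3c(C)cc(OC)cc3OC)c(C)nn12`: 2.14 nM

Of the compounds shown here, two have so far been tested in an assay on cell membranes for displacement of a labelled ligand from corticotropin-releasing factor receptor 1 (Rattus norvegicus); a lower number here means a stronger inhibitor, a higher number a weaker inhibitor. Compound 1 gives 1 nM, the lowest of the two numbers. Compound 2 gives 2.14 nM, a higher number, and the gap between the two lies beyond the usual scatter of this assay. The two compounds also differ in more than one place, so no single structural change can be read from this pair.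

A third compound, compound 3 `CCC(CC)Nc1nc(C)nc2c(-c3cc(F)c(OC)cc3C)c(C)nn12`, has not yet been measured. It differs from compound 1 in one place only: methyl in place of chloro on an aromatic carbon. For the measured compounds named here, no measured pair shows this particular exchange, so the data give no direct guide to its effect. The expected step from compound 1 to compound 3 in this assay is a 1.6-fold higher number from compound 1 to compound 3 (0.20 log units; within the scatter), a small shift towards a higher number, possibly no more than the scatter itself. On that basis compound 3 is expected to give 1.6 nM, with a likely range from 0.5 nM to 5 nM.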

Compound 3, half-maximal inhibitory concentration: 1.9 nM
Compound 3: the middle estimate sits 1.2-fold (0.07 log units) below what was measured, within the range that was stated.
By their numbers in this assay, from the lowest: compounds 1, 3 and 2 (each within the scatter of the next, the first and the last beyond it).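

In this assay, for the compounds shown here, the exchange of chloro for methyl gives a 1.9-fold higher number from compound 1 to compound 3 (0.28 log units; within the scatter) and so provides the first single change that can be read. At this aromatic carbon, ortho to a large group and para to a fluoro group, the assay does not separate chloro from methyl, so binding here does not depend on having one of these two groups rather than the other. This holds for this one pair only, and nothing available explains why the two groups give values so alike.

The compounds shown leave open whether the same carbon would also tolerate a group of a different kind, such as an ethyl group, an amine or a carboxylic acid, or plain hydrogen, any of which would test how much this position can change before the number moves beyond the scatter. Going by these compounds alone, it also remains open whether methyl and chloro would stay this close on a compound with a different amine chain on the shared core, such as the one in compound 2.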